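Swapping halogens for a hydroxyl on the hydrazone aryl ring

The source may report more compounds than this note shows. Statements on the series, on what has been measured and on what is new or still open speak of the compounds shown alone.

Compound 1 `CN(C)CCn1cnnc1-c1cc(Oc2ccc(NC(=O)N/N=C/c3ccc(F)cc3F)cc2F)ccn1` was tested in a functional assay on HT-29 cells (Homo sapiens) for cytotoxicity, read by MTT assay, with a stated time of 72 h (a lower number here means a stronger inhibitor, a higher number a weaker inhibitor), and gave 960 nM. Among the three compounds measured, compound 1 has the highest number, meaning the weakest inhibition. Compound 2 `CN(C)CCn1cnnc1-c1cc(Oc2ccc(NC(=O)N/N=C/c3cccc(Cl)c3Cl)cc2F)ccn1` gave 130 nM, and compound 3 `CN(C)CCn1cnnc1-c1cc(Oc2ccc(NC(=O)N/N=C/c3ccc(F)cc3Cl)cc2F)ccn1` gave 510 nM. The step of a 7.4-fold lower number from compound 1 to compound 2 (0.87 log units; beyond the scatter) is a real gain, whereas a 1.9-fold lower number from compound 1 to compound 3 (0.27 log units; within the scatter) sits within the scatter of the assay, and a 3.9-fold higher number from compound 2 to compound 3 (0.59 log units; beyond the scatter) again separates the two.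

Compound 4 `CN(C)CCn1cnnc1-c1cc(Oc2ccc(NC(=O)N/N=C/c3cccc(O)c3)cc2F)ccn1` has not yet been measured. It differs from compound 1 in one place: 3-hydroxyphenyl in place of 2,4-difluorophenyl on a carbon with a double bond to nitrogen.

The measured steps bear only loosely on this change. Both earlier steps kept halogens on the ring and merely moved or exchanged them; none of them introduced a hydroxyl. The only clear lesson is that the pattern on this ring can shift the number by a modest amount, as the step from compound 1 to compound 2 shows, while a smaller exchange left it within the scatter. For the measured compounds named here, with no precedent for a hydroxyl, a step of no more than modest size in either direction is expected, and the estimate is placed near compound 1 with a wide range.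

Compound 4 is therefore expected to give 800 nM, between 200 nM and 3500 nM, which means an expected step of a 1.2-fold lower number from compound 1 to compound 4 (0.08 log units; within the scatter).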

Compound 4, half-maximal inhibitory concentration: 330 nM
Compound 4: middle estimate off by 2.4-fold (0.38 log units), on the high side; the range from low to high includes it.
By their numbers in this assay, from the lowest: compound 2; then compounds 4, 3 and 1 (each within the scatter of the next, the first and the last beyond it).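

Compound 4 shows that this position does not need a halogen, at least in this assay: the step (a 2.9-fold lower number from compound 1 to compound 4 (0.46 log units; beyond the scatter)) is a real gain from a ring that carries a hydroxyl and no fluorine or chlorine, and that adds a hydrogen-bond donor on the carbon with a double bond to nitrogen. The halogen-free ring cannot be told apart from the 2-chloro-4-fluorophenyl ring (a 1.5-fold lower number from compound 3 to compound 4 (0.19 log units; within the scatter)), yet it does not match the 2,3-dichlorophenyl ring (a 2.5-fold higher number from compound 2 to compound 4 (0.40 log units; beyond the scatter)), so the halogens here cannot be treated as interchangeable with the hydroxyl or with each other. Nothing available here explains any of these differences.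

Going by these compounds, it stays open whether the hydroxyl itself produces the gain over compound 1 or whether the gain comes simply from losing the two fluorines, a question that a plain phenyl ring, or a methoxy group or an amine in place of the hydroxyl, would help to settle. Also open, on these data alone, is what a ring carrying both a hydroxyl and a chlorine would give.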